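The source may report more compounds than this note shows. Statements on the series, on what has been measured and on what is new or still open speak of the compounds shown alone.

Measured so far in a functional assay on the whole organism (strain CF-1) with Mus musculus as the target; on this read-out lower numbers stand for an effect already at smaller amounts and higher numbers for an effect only at larger amounts of compound:
compound 1 `Cc1nnc(CN2CCCC2)n1-c1ccc(Cl)cc1C(=O)c1ccccc1Cl` gives 18 mg/kg
compound 2 `Cc1nnc(CN(C)C)n1-c1ccc(Cl)cc1C(=O)c1ccccc1Cl` gives 3.2 mg/kg

Among these two numbers compound 2 holds the lower one, and the step of a 5.6-fold lower number from compound 1 to compound 2 (0.75 log units; beyond the scatter) that separates it from compound 1 is beyond the scatter. The unmeasured compound 3 `CN(C)Cc1nnc(C2CC2)n1-c1ccc(Cl)cc1C(=O)c1ccccc1Cl` departs from compound 2 by cyclopropyl in place of methyl on an aromatic carbon. Going by the values given here, no measured step touches that place on the shared core: the only step known, a 5.6-fold lower number from compound 1 to compound 2 (0.75 log units; beyond the scatter), exchanges the amine on the saturated chain carbon and leaves the methyl as it is, so it says nothing about what a cyclopropyl in that position does. With nothing to lean on beyond the number for compound 2 itself, the step of a 1.3-fold higher number from compound 2 to compound 3 (0.10 log units; within the scatter) is expected to stay within the usual scatter of this assay, in no firm direction. Compound 3 is therefore estimated at 4 mg/kg in this assay. The expected range for compound 3 runs from 1.5 mg/kg to 12 mg/kg. Among the compounds with values here, that range is kept wide, since the data hold no step that bears on this change.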

Compound 3, dose for half-maximal effect: 7.1 mg/kg
The estimate for compound 3 lay 1.8-fold (0.25 log units) below the measured number, within the range that was stated.
By their numbers in this assay, from the lowest: compound 2; then compound 3; then compound 1.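

In this assay, the aromatic carbon between two ring nitrogen atoms now has a measured result of its own: cyclopropyl in place of methyl gives a 2.2-fold higher number from compound 2 to compound 3 (0.35 log units; beyond the scatter). The step is beyond the scatter, so this position does respond to the exchange of its substituent, and here the three-carbon ring with its larger count of heavy atoms goes with an effect only at a larger dose. Nothing in the available data explains this shift.

Going by these compounds, what remains open is whether the shift follows the added carbon atoms or the three-membered ring itself, which an ethyl or isopropyl group on the same aromatic carbon would help to separate, while a hydrogen there would show what the methyl of compound 2 contributes. Also open, on these data alone, is whether the change at this position has the same effect with pyrrolidin-1-yl on the chain carbon in place of dimethylamino, and whether another amine there, such as morpholine, would alter the picture.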